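Adding isopropyl to a well-tolerated phenyl compound

The source may hold more compounds than are shown below. What is called first, only, known or untested is meant among the compounds shown, and "the series" means these compounds.

So far, three compounds sharing one core have been measured in an ADME assay on cells (Macrophage) for cytotoxicity, read by resazurin assay, with a stated time of 48 h; a higher number here means that more compound is tolerated, a lower number that less compound is tolerated. There, compound 1 `COc1ccc(-c2cc(-c3ccc(OCc4cn(Cc5ccccc5)nn4)cc3O)nc(N)n2)cc1` gives 42700 nM, compound 2 `Nc1nc(-c2ccc(OCc3cn(Cc4ccccc4)nn3)cc2O)cc(-c2cccc3ccccc23)n1` gives 71300 nM and compound 3 `Nc1nc(-c2ccccc2)cc(-c2ccc(OCc3cn(Cc4ccccc4)nn3)cc2O)n1` gives 76500 nM, so compound 3 stands level with the other two within the scatter.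

Compound 4 `CC(C)c1ccc(-c2cc(-c3ccc(OCc4cn(Cc5ccccc5)nn4)cc3O)nc(N)n2)cc1` changes compound 3 in one place: isopropyl in place of hydrogen on an aromatic carbon. Isopropyl takes the place of hydrogen on an aromatic carbon, turning phenyl into 4-isopropylphenyl.

Going by the values given here, two measured steps bear on this. Compound 1 carries 4-methoxyphenyl, so the closest comparison is the swap of methoxy for hydrogen, a 1.8-fold higher number from compound 1 to compound 3 (0.25 log units; within the scatter). A much larger swap of the same aryl group, naphthalen-1-yl to phenyl, gave a 1.1-fold higher number from compound 2 to compound 3 (0.03 log units; within the scatter). Neither step exceeds the scatter in this assay, so no step beyond the scatter is expected here.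

The expected change is a 1.4-fold lower number from compound 3 to compound 4 (0.14 log units; within the scatter). For compound 4 the estimate is 55000 nM, with an expected range from 27000 nM to 110000 nM.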

Compound 4, half-maximal cytotoxic concentration: > 100000 nM
Compound 4 gave a limit, no number (the forecaster's own chance of this, stated with the estimate: 10%); at least 1.8-fold (0.25 log units) between middle value and limit.
By their numbers in this assay, from the lowest: compounds 1, 2 and 3 (each within the scatter of the next). At a limit, above all of these: compound 4.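

Compound 4 reached a limit of the assay rather than giving a number: the limit of > 100000 nM in this assay, at which 1 of the 4 values shown sits. Going by these compounds alone, replacing methoxy with isopropyl gives an at least 2.3-fold higher number from compound 1 to compound 4 (0.36 log units; beyond the scatter), and this is the first step beyond the scatter, which shows that the group para to a large group can make a measurable difference in how much compound is tolerated. By contrast, adding isopropyl to phenyl gives an at least 1.3-fold higher number from compound 3 to compound 4 (0.11 log units; that floor lies within the scatter) and replacing naphthalen-1-yl gives an at least 1.4-fold higher number from compound 2 to compound 4 (0.14 log units; that floor lies within the scatter), so neither change can yet be told apart from the scatter.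

On these data alone, how far the true value of compound 4 lies past its limit remains unknown. Also open, as far as these compounds go, is how an amine, a carboxylic acid or a longer chain in the same position would compare.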